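Stability series: truncation of the sulfonyl aryl group

A few compounds are considered here, and "the series" means these few. Any claim that something is new, unique, unknown or untested is made for them only; others in the source may bear on it.

Compound 1 `CCCCc1nc(=O)c(S(=O)(=O)c2ccc(-c3ccnc(NC(=O)C4CC4)c3)cc2)c(O)n1-c1c(OC)cccc1OC` gives 72% in an ADME assay on microsomes from liver (Mus musculus) for metabolic stability, using NADPH, with a stated time of 10 min; on this read-out lower numbers stand for a less stable compound and higher numbers for a more stable compound. Compound 2 `CCCCc1[nH]c(=O)c(S(=O)(=O)c2ccc(-n3ccccc3=O)cc2)c(O)c1-c1c(OC)cccc1OC` gives 75% in this assay; the two numbers lie within the scatter of each other, so no order between them can be read. Compound 3 `CCCCc1nc(=O)c(S(=O)(=O)c2ccccc2)c(O)n1-c1c(OC)cccc1OC` is not yet measured. It differs from compound 1 in one place: hydrogen in place of 2-((cyclopropylcarbonyl)amino)pyridin-4-yl on an aromatic carbon. Among the compounds with values here, no step of this kind is measured; in this assay the expected step is small, in either direction or none beyond the scatter, a number 2 percentage points lower from compound 1 to compound 3 (within the scatter). Compound 3 is estimated at 70%, between 45% and 90%.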

Compound 3, percent of the compound remaining: 79%
Beside the measured number, compound 3's estimate is 9 percentage points below it; measured number inside the range.
By their numbers in this assay, from the lowest: compounds 1, 2 and 3 (each within the scatter of the next).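

Hydrogen in place of 2-((cyclopropylcarbonyl)amino)pyridin-4-yl gives a number 7 percentage points higher from compound 1 to compound 3 (within the scatter) in this assay. Within the data shown here, this is the first one-place step: at this aromatic carbon, the read-out holds without those 12 heavy atoms, so the group is not required for this level of stability. No measured evidence bears on the reason for this result.

Still open, on these data alone, is how a small substituent such as fluorine, or a carboxylic acid or an amine, would behave on the same carbon. As far as these compounds go, whether the step holds on other cores also remains open.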